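The compounds below may be only part of what the source reports. "The series", "measured", "known", "first", "only" and "open" are said of these compounds alone.

In a functional assay on Bel-7402 cells (Homo sapiens) for cytotoxicity, read by MTT assay, with a stated time of 48 h (on this read-out lower numbers stand for stronger inhibition and higher numbers for weaker inhibition), compound 1 `CCn1cc(-c2nc3ccccc3[nH]2)c(=O)c2cc(F)c(N3CCNCC3)cc21` gives 27400 nM, the second highest of the three numbers here. Compound 2 `CCn1cc(-c2nc3ccccc3[nH]2)c(=O)c2cc(F)c(N3CCNC(C)C3)c(F)c21` gives 30200 nM, which lies within the usual scatter of the number for compound 1, while compound 3 `CCn1cc(-c2nc3ccccc3o2)c(=O)c2cc(F)c(N3CCNC(C)C3)c(F)c21` gives 5700 nM. Compound 4 `CCn1cc(-c2nc3ccccc3s2)c(=O)c2cc(F)c(N3CCNCC3)cc21` differs from compound 1 in one place: 1,3-benzothiazol-2-yl in place of 1H-benzimidazol-2-yl on an aromatic carbon. Among the measured compounds shown here, the only measured step that bears on this exchange is a 5.3-fold lower number from compound 2 to compound 3 (0.72 log units; beyond the scatter), which also swapped out the 1H-benzimidazol-2-yl group on the same aromatic carbon of the shared core. By that analogy, the expected step is a 3.9-fold lower number from compound 1 to compound 4 (0.59 log units; beyond the scatter), a modest drop rather than no change. The estimate for compound 4 is 7000 nM, with a range from 2500 nM to 20000 nM.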

Compound 4, half-maximal inhibitory concentration: 24300 nM
The estimate for compound 4 lay 3.5-fold (0.54 log units) below the measured number; measured number outside the range, above it.
By their numbers in this assay, from the lowest: compound 3; then compounds 4, 1 and 2 (each within the scatter of the next).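

In this assay, the step of a 1.1-fold lower number from compound 1 to compound 4 (0.05 log units; within the scatter) shows that, on this aromatic carbon, 1,3-benzothiazol-2-yl can replace 1H-benzimidazol-2-yl without a change beyond the scatter. Leaving out 1H-benzimidazol-2-yl therefore does not by itself bring a lower number, unlike the exchange for 1,3-benzoxazol-2-yl on a different core, a 5.3-fold lower number from compound 2 to compound 3 (0.72 log units; beyond the scatter). Nothing available here explains why the two exchanges differ. From the compounds shown here alone, whether each exchange would give the same result on the other core stays open. So does the effect of a carboxylic acid or an amide on this carbon.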